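The compounds below may be only part of what the source reports. "The series", "measured", "known", "first", "only" and "open" are said of these compounds alone.

Compounds measured in an assay on SK-N-MC cells for inhibition of Neuropeptide Y receptor type 1 (Homo sapiens); a lower number here means a stronger inhibitor, a higher number a weaker inhibitor:

- compound 1 `COC(=O)C1=C(C)N=C(C)/C(=C(/O)OC)C1c1cccc(N/C(=N/CCNC2CCN(c3ccccc3C)CC2)NC#N)c1` gives 4 nM
- compound 2 `COC(=O)C1=C(C)N=C(C)/C(=C(/O)OC)C1c1cccc(N/C(=N/CCNC2CCN(c3ccccc3C#N)CC2)NC#N)c1` gives 3 nM

Among the measured compounds shown here, compound 2 has the lowest of the two numbers, but its only neighbour is compound 1, and the step of a 1.3-fold lower number from compound 1 to compound 2 (0.12 log units; within the scatter) falls within the scatter, so the two cannot be told apart. Compound 3 `COC(=O)C1=C(C)N=C(C)/C(=C(/O)OC)C1c1cccc(N/C(=N/CCNC2CCN(c3cccc(Cl)c3)CC2)NC#N)c1` differs from compound 2 by 3-chlorophenyl in place of 2-cyanophenyl on an amine nitrogen in a ring. For the measured compounds named here, the one measured step exchanged groups on the same aromatic ring and gave the small shift a 1.3-fold lower number from compound 1 to compound 2 (0.12 log units; within the scatter); it shows that this ring tolerated one swap, but nothing measured covers a chlorine or a change of its position, so the bearing is indirect. On that basis no step beyond the scatter is expected for compound 3, with the chance of a modestly higher number, and compound 3 is estimated at 5 nM (range 1.5 nM to 16 nM), an expected step of a 1.7-fold higher number from compound 2 to compound 3 (0.22 log units; within the scatter).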

Compound 3, half-maximal inhibitory concentration: 8 nM
Compound 3: middle estimate off by 1.6-fold (0.20 log units), on the low side, and the stated range covers the measured number.
By their numbers in this assay, from the lowest: compounds 2, 1 and 3 (each within the scatter of the next, the first and the last beyond it).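

In this assay, among the compounds shown here, the change to 3-chlorophenyl gives the first step at this ring nitrogen that lies beyond the scatter, a 2.7-fold higher number from compound 2 to compound 3 (0.43 log units; beyond the scatter), though it is modest in size. Measured from the 2-methylphenyl group instead, the same swap stays within the scatter, a 2.0-fold higher number from compound 1 to compound 3 (0.30 log units; within the scatter), so this position accepts a chlorine-bearing ring with at most a small cost in binding, and the outcome depends partly on which compound serves as the reference. No measurement on hand accounts for the shift.

This swap changes both the substituent and its place on the ring, so the two effects cannot be separated. A 2-chlorophenyl or 3-cyanophenyl group would separate them, while an unsubstituted phenyl group would show what any substituent here contributes.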